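This account rests on a few compounds, and the source may have more. Where it says the series, first, only, none or still open, it means among the compounds named here.

Measured in a functional assay on A549 cells (Homo sapiens) for inhibition, read by MTT assay, with a stated time of 72 h; a higher number here means a weaker inhibitor, a lower number a stronger inhibitor:
- compound 1 `O=[N+]([O-])c1ccc(-c2nnc(SCCCN3CCN(c4nc5ccccc5s4)CC3)o2)cc1`: 96600 nM
- compound 2 `Oc1ccc(-c2nnc(SCCCN3CCN(c4nc5ccccc5s4)CC3)o2)cc1`: 62100 nM

Among the compounds with values here, only two numbers are available so far, and compound 2 gives 62100 nM. Within the data shown here, it cannot be separated from compound 1, as the one measured step shows: a 1.6-fold lower number from compound 1 to compound 2 (0.19 log units; within the scatter). Both compounds share the same core and differ only in one small group.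

Compound 3 `O=C(NCc1nnc(SCCCN2CCN(c3nc4ccccc4s3)CC2)o1)c1ccccc1` keeps most of that structure but carries a more sweeping change: benzamidomethyl in place of 4-hydroxyphenyl on an aromatic carbon. In words, this is benzamidomethyl in place of 4-hydroxyphenyl on an aromatic carbon of the five-membered aromatic ring with 2 nitrogen and 1 oxygen.

The measured step bears on this only loosely. It swapped nitro for hydroxy, whereas here the whole 4-hydroxyphenyl leaves. Among the measured compounds shown here, nothing measured so far tests such a replacement, so no direction can be argued from the data. With compound 2 at 62100 nM as the starting point, no step beyond the scatter is expected in this assay, though with wide uncertainty. The expected change is a 1.0-fold lower number from compound 2 to compound 3 (0.01 log units; within the scatter). For compound 3 the estimated value is 60000 nM, with an expected range from 20000 nM to 150000 nM.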

Compound 3, half-maximal inhibitory concentration: 88700 nM
The estimate for compound 3 lay 1.5-fold (0.17 log units) below the measured number; the measured number falls inside the stated range.
By their numbers in this assay, from the lowest: compounds 2, 3 and 1 (each within the scatter of the next).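

In this assay, swapping the whole 4-hydroxyphenyl for benzamidomethyl gives a 1.4-fold higher number from compound 2 to compound 3 (0.15 log units; within the scatter) and swapping 4-nitrophenyl for the same group gives a 1.1-fold lower number from compound 1 to compound 3 (0.04 log units; within the scatter), so neither replacement can be told apart from repeat-measurement noise. The earlier step changed only a small group on the outer ring, whereas this one replaces the whole group on the aromatic carbon of the five-membered ring, adding heavy atoms and a carbonyl while keeping a six-membered aromatic ring of carbon only, and the three compounds still cannot be separated. Nothing available explains why the readout stays so flat across this larger change.

As far as these compounds go, all three groups at this position carry a six-membered aromatic ring of carbon only, so it remains open how the number would respond to a group without that ring, such as a simple amine or a carboxylic acid on the same carbon. Because compound 1, compound 2 and compound 3 all lie within the scatter of one another, it is also unknown whether any group at this position can move the number clearly in either direction.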